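The compounds below may be only part of what the source reports. "The series", "measured", "known", "first", "only" and "open" are said of these compounds alone.

The study concerns a shared core, carried by compound 1 `O=C1CSc2cc(OCC3CCCCC3)ccc2N1` and compound 2 `O=C1CSc2cc(OCCCc3ccccc3)ccc2N1`. Both were tested in an assay on isolated protein for inhibition of Amine oxidase [flavin-containing] B (Homo sapiens), read by fluorescence and spectrophotometry, with a stated time of 20 min; on this read-out lower numbers stand for stronger inhibition and higher numbers for weaker inhibition. In this assay compound 1 gives 24 nM, and compound 2 gives 20 nM. Of the two numbers, that of compound 1 is the higher, yet the nearest, compound 2, lies within the scatter of it, so the two compounds cannot be told apart on these data.

The step from compound 1 leads to compound 3 `COc1ccc2c(c1)SCC(=O)N2`. The change is hydrogen in place of cyclohexyl on a saturated chain carbon bound to an oxygen on an aromatic ring. Among the compounds with values here, no measured pair in this set shows a change of this kind, so its size can be judged only from the structures, and both compounds measured so far keep a sizeable group on that chain carbon. The account therefore expects a step well beyond the scatter, toward weaker inhibition, and the expected step is a 100-fold higher number from compound 1 to compound 3 (2.02 log units; beyond the scatter). Compound 3 is accordingly estimated at 2500 nM, with an expected range from 400 nM to 15000 nM.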

Compound 3, half-maximal inhibitory concentration: 42600 nM
The estimate for compound 3 lay 17-fold (1.23 log units) below the measured number, outside the stated range (above it).
By their numbers in this assay, from the lowest: compounds 2 and 1 (each within the scatter of the next); then compound 3.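

In this assay, putting hydrogen in place of cyclohexyl on a saturated chain carbon bound to an oxygen on an aromatic ring gives a 1800-fold higher number from compound 1 to compound 3 (3.25 log units; beyond the scatter) and is a large step. Compound 1 and compound 2 could not show this, as both keep a sizeable group on that chain carbon; the new pair shows that, for compound 1, the inhibition depends heavily on the cyclohexyl at this position, and that the shared core carrying only hydrogen there is far weaker, with compound 3 at 42600 nM in this assay as the reading. Nothing at hand accounts for the size of this step.

The compounds shown leave open how the number moves between these two ends, since they give no reading for a small group on that chain carbon, such as a methyl, an ethyl or a cyclopropyl. They also leave open whether the position accepts anything other than a carbon-only group, for example an amine or a carboxylic acid at the end of a longer chain.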